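Isoxazole ether series: amide to benzylamine with a chain acid

A few compounds are considered here, and "the series" means these few. Any claim that something is new, unique, unknown or untested is made for them only; others in the source may bear on it.

Measured so far:
Compound 1, `CC(C)c1onc(-c2c(Cl)cccc2Cl)c1COc1ccc(N(C)C(=O)c2ccc(C(=O)O)cc2)c(C(F)(F)F)n1` — in a functional assay on HEK293 cells for agonist activity at Bile acid receptor (Homo sapiens) (on this read-out higher numbers stand for an effect only at larger amounts of compound and lower numbers for an effect already at smaller amounts), compound 1 gives 316 nM.
Compound 2, `CC(C)c1onc(-c2c(Cl)cccc2Cl)c1COc1ccc(N(C)C(=O)c2cccc(C(=O)O)c2)c(C(F)(F)F)n1` — in this assay compound 2 gives 571 nM.

Within the data shown here, compound 2 has the higher of the two numbers, but the single step recorded, a 1.8-fold higher number from compound 1 to compound 2 (0.26 log units; within the scatter), lies within the scatter, so the two compounds are indistinguishable on these data.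

Compound 3, `CC(C)c1onc(-c2c(Cl)cccc2Cl)c1COc1ccc(N(C)Cc2ccc(CCC(=O)O)cc2)c(C(F)(F)F)n1`, differs from compound 2 by 4-(2-carboxyethyl)benzyl in place of (3-carboxyphenyl)carbonyl on a nitrogen on an aromatic ring. Among the measured compounds shown here, no measured step touches this change: the one step known only moves the acid around the ring of the amide, and it was within the scatter. Going by these compounds, the replacement of the carbonyl by a saturated chain carbon and the move of the acid onto a two-carbon chain is untested here, so the expectation rests on the series baseline alone with wide uncertainty. Compound 3 is estimated at 700 nM in this assay, within 150 nM to 3500 nM. That corresponds to an expected step of a 1.2-fold higher number from compound 2 to compound 3 (0.09 log units; within the scatter), likely no change beyond the scatter.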

Compound 3, half-maximal effective concentration: 35 nM
Compound 3: the middle estimate sits 20-fold (1.30 log units) above what was measured, and the stated range ends above it.
By their numbers in this assay, from the lowest: compound 3; then compounds 1 and 2 (each within the scatter of the next).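

In this assay, among these compounds, the group on the nitrogen on an aromatic ring proves a far stronger lever than the place of the acid on the amide ring: 4-(2-carboxyethyl)benzyl in place of (3-carboxyphenyl)carbonyl gives a 16-fold lower number from compound 2 to compound 3 (1.21 log units; beyond the scatter) and in place of (4-carboxyphenyl)carbonyl gives a 9.0-fold lower number from compound 1 to compound 3 (0.96 log units; beyond the scatter), whereas the one earlier step stayed within the scatter. The carbonyl on this nitrogen is thus not needed for activity in this series, and a saturated chain carbon is accepted there. Nothing on hand accounts for the gain.

The change swaps the carbonyl for a saturated chain carbon and also moves the carboxylic acid from the ring onto a chain, and the compounds shown do not separate these two parts. Still open, going by these compounds, are a benzyl group carrying the carboxylic acid directly on its ring and a longer chain ending in the acid.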